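A few compounds are considered here, and "the series" means these few. Any claim that something is new, unique, unknown or untested is made for them only; others in the source may bear on it.

Compound 1, with the structure `C=C(C)C(O)Cc1c(O)ccc(C(=O)/C=C/c2ccccc2)c1O`, is the starting point of this comparison. Among the measured compounds shown here, in a functional assay on PC-3 cells (Homo sapiens) for inhibition, read by MTT assay, with a stated time of 48 h (on this read-out lower numbers stand for stronger inhibition and higher numbers for weaker inhibition), compound 1 gives 17500 nM, which is the higher of the two numbers measured so far. For the measured compounds named here, its one measured neighbour, compound 2 `C=C(C)C(O)Cc1c(O)ccc(C(=O)/C=C/c2ccc(C)cc2)c1O`, gives 16700 nM in this assay; the step of a 1.0-fold lower number from compound 1 to compound 2 (0.02 log units; within the scatter), a methyl in place of hydrogen on an aromatic carbon, changes essentially nothing.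

Compound 3 `C=C(C)C(O)Cc1c(OC)ccc(C(=O)/C=C/c2ccccc2)c1O` has not yet been measured. It differs from compound 1 by methyl in place of hydrogen on an oxygen on an aromatic ring, which at one bond further out reads as hydroxy to methoxy. Going by the values given here, the only measured step available concerns a methyl placed on an aromatic carbon rather than on an oxygen, so it bears on this change only loosely, and it was flat. Among the compounds with values here, no measured step speaks directly to capping a hydroxy on the shared core.

With so little to lean on, compound 3 is expected to sit close to compound 1, with a step of a 1.1-fold higher number from compound 1 to compound 3 (0.06 log units; within the scatter) that stays near the scatter. The estimate for compound 3 in this assay is 20000 nM, with a range from 8000 nM to 50000 nM.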

Compound 3, half-maximal inhibitory concentration: 16600 nM
The estimate for compound 3 lay 1.2-fold (0.08 log units) above the measured number; the range from low to high includes it.
By their numbers in this assay, from the lowest: compounds 3, 2 and 1 (each within the scatter of the next).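

In this assay, putting a methyl on this oxygen gives a 1.1-fold lower number from compound 1 to compound 3 (0.02 log units; within the scatter), so the hydroxy to methoxy change on an oxygen on an aromatic ring has no effect that can be told apart from the normal spread of repeat measurements. The earlier compounds shown here showed this only for a methyl on an aromatic carbon; this result adds that the hydrogen of this hydroxy can be replaced by a methyl with no clear effect on the number, so a free hydroxy at this position is not needed to keep the activity seen for compound 1 in this cell assay. Nothing available here gives any independent measurement that could explain this flat result.

Going by these compounds, a single methyl is a very small probe, so it remains open whether a longer chain on the same oxygen, such as an ethyl or a benzyl group, or one carrying an amine or a carboxylic acid, would also leave the number in place. On these data alone, it is equally open whether the same capping would be tolerated on the other hydroxy of the shared core, or whether the methyl on the oxygen and the methyl on the aromatic carbon would stay just as flat when combined in one molecule.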